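Swapping fluoro for hydroxy on a tetralone-derived scaffold

This account rests on a few compounds, and the source may have more. Where it says the series, first, only, none or still open, it means among the compounds named here.

Measured compounds:
compound 1, `O=C1/C(=C/c2cccc(F)c2)CCc2ccc(O)cc21`, 830 nM
compound 2, `O=C1/C(=C/c2ccc(C(F)(F)F)cc2)CCc2ccc(O)cc21`, > 10000 nM

The study measures inhibition in a functional assay on RAW264.7 cells (Mus musculus) for inhibition; a higher number here means a weaker inhibitor, a lower number a stronger inhibitor. Compound 1 gives 830 nM, the only numerical result among the two compounds shown. Compound 2 gives > 10000 nM; this is a limit of the assay and not a number, at which one of the two values sits, described as the limit of > 10000 nM in this assay, at which 1 of the 2 values shown sits.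

Compound 3, `O=C1/C(=C/c2cccc(O)c2)CCc2ccc(O)cc21`, is not yet measured. It differs from compound 1 by hydroxy in place of fluoro on an aromatic carbon, meta to a large group. Within the data shown here, no pair of measured compounds differs in just this one place, so no measured step tells how large a change to expect. The account therefore expects, from compound 1 to compound 3, a step of a 1.8-fold higher number from compound 1 to compound 3 (0.26 log units; within the scatter) in this assay, modest and within or close to the scatter. Compound 3 is estimated at 1500 nM in this assay, with a range from 400 nM to 6000 nM.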

Compound 3, half-maximal inhibitory concentration: 810 nM
Beside the measured number, compound 3's estimate is 1.9-fold (0.27 log units) above it; the measured number falls inside the stated range.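

The result gives the series its first step in a single place, a 1.0-fold lower number from compound 1 to compound 3 (0.01 log units; within the scatter), read in this assay. It shows that, on this aromatic carbon meta to a large group, fluoro and hydroxy cannot be told apart in this read-out, even though hydroxy brings a hydrogen-bond donor and acceptor and fluoro brings neither. Nothing available gives a reason why the two groups match here.

What the compounds shown leave open is whether this place accepts groups beyond these two, such as an amine, a carboxylic acid or a methoxy group, or whether the match is confined to fluoro and hydroxy. They also leave open whether the same exchange of hydroxy for fluoro would give a similar step on other aromatic carbons of the shared core, as this single pair speaks for one place in one assay only.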